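One Added Methyl on a Saturated Chain

The source may report more compounds than this note shows. Statements on the series, on what has been measured and on what is new or still open speak of the compounds shown alone.

Two compounds sharing one core have so far been taken through an ADME assay on HepG2 cells (Homo sapiens) for cytotoxicity, read by MTT assay, with a stated time of 72 h; on this read-out higher numbers stand for lower toxicity in this test and lower numbers for higher toxicity in this test. There compound 1 (`Cc1ccc(-c2cc3nc(N)[nH]c(=O)c3s2)cc1`) gave "nd(insoluble)" (no result reported) and so offers no number for comparison. Among the compounds with values here, compound 2 (`CCCCCCNc1nc2cc(-c3ccc(C)cc3)sc2c(=O)[nH]1`) gave 10600 nM as the only number available, which leaves it with no measured neighbour to stand against. The next compound, compound 3 (`CCCCCCCNc1nc2cc(-c3ccc(C)cc3)sc2c(=O)[nH]1`), differs from compound 2 by a single change (methyl in place of hydrogen on a saturated chain carbon, six bonds along the chain from a nitrogen on an aromatic ring): methyl in place of hydrogen on a saturated chain carbon, six bonds along the chain from a nitrogen on an aromatic ring. Resting on compound 2 at 10600 nM alone, with no measured step as a guide, the step of a 1.2-fold lower number from compound 2 to compound 3 (0.07 log units; within the scatter) in this assay is expected to stay within the usual scatter, with a slight lean toward lower numbers. For compound 3 the estimate is 9000 nM with an expected range from 4000 nM to 20000 nM as the upper end.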

Compound 3, half-maximal cytotoxic concentration: 6800 nM
For compound 3 the middle estimate is 1.3-fold (0.12 log units) above the measured one; measured number inside the range.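

In this assay the chain now has its first measured step, a 1.6-fold lower number from compound 2 to compound 3 (0.19 log units; within the scatter), and the two compounds cannot be told apart on this read-out. Methyl in place of hydrogen on a saturated chain carbon, six bonds along the chain from a nitrogen on an aromatic ring, is therefore a change this position tolerates without a readable shift, at least for this one pair, something neither compound 1, with no number, nor compound 2, standing alone, could show. No measurement at hand accounts for the size of this step.

One step cannot show whether a longer chain would also stay within the scatter. It also leaves open how an amine or a carboxylic acid in this place would read.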